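Phenyl for methyl on the aryl ether oxygen

The source may hold more compounds than are shown below. What is called first, only, known or untested is meant among the compounds shown, and "the series" means these compounds.

Compound 1, `CCCn1ccc2cc(-c3cccnc3)cc(Cl)c2c1=O`, in a functional assay on CHO cells for agonist activity at metabotropic glutamate receptor 2 (Homo sapiens), read by GTPgammaS binding (a lower number here means a smaller maximal response, a higher number a larger maximal response), gives 83%.
Compound 2, `CCCn1ccc2cc(-c3cnc(OC)c(F)c3)cc(Cl)c2c1=O`, in this assay gives 75%.
Compound 3, `CCCn1ccc2cc(-c3ccc(OC)cc3)cc(Cl)c2c1=O`, in this assay gives 136%.

Three compounds share the core of compound 1 and differ only in the aromatic ring attached to it. Compound 3 stands highest of the three in this assay: its number lies beyond the scatter above that of compound 1, its nearest neighbour, and further still above that of compound 2. No pair among these three differs in just one place, so no single step between measured compounds can be stated; what the values show is that compound 3 reaches a larger maximal response than either of the other two.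

Compound 4, `CCCn1ccc2cc(-c3ccc(Oc4ccccc4)cc3)cc(Cl)c2c1=O`, is not yet measured. It arises from compound 3 by the change (phenyl in place of methyl on an oxygen on an aromatic ring), that is, methoxy becomes phenoxy. Among the measured compounds shown here, nothing among the measured compounds tests this kind of change, so the direction of the step in this assay is uncertain. Given the high value of compound 3, 136%, a drop of moderate size is thought more likely than a further rise, but a result within the scatter would not surprise.

Compound 4 is expected to give 115% in this assay, within the range 75% to 150%. The step this estimate implies, a number 21 percentage points lower from compound 3 to compound 4 (beyond the scatter), is expected to be modest and downward.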

Compound 4, largest response reached (Emax), in percent of the reference or control that the assay uses: 88%
For compound 4 the middle estimate is 27 percentage points above the measured one, and the stated range covers the measured number.
By their numbers in this assay, from the lowest: compounds 2, 1 and 4 (each within the scatter of the next, the first and the last beyond it); then compound 3.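

Among the compounds shown here, replacing methyl with phenyl on an oxygen on an aromatic ring gives a number 48 percentage points lower from compound 3 to compound 4 (beyond the scatter) in this assay, the first step here between two measured compounds that differ in one place. This shows that the maximal response depends on what this oxygen carries: where the earlier values could only be set side by side across different aromatic rings, methoxy to phenoxy isolates a single exchange, in which one carbon leaves and a six-membered aromatic ring enters, and that exchange alone moves the number beyond the scatter. Nothing available bears on why the response falls with this change.

As far as these compounds go, it stays open whether an ethyl, cyclopropyl or benzyl group on this oxygen would keep the response near that of compound 3 or bring it down towards that of compound 4, so a single step cannot say whether the phenyl ring as such or some other feature of the exchange goes with the fall. Also open, from the compounds shown here alone, is whether phenyl in place of methyl on the oxygen of compound 2 would give a step of like direction and size.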